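Methyl in Place of Methoxy: What Inhibition to Expect

The compounds below may be only part of what the source reports. "The series", "measured", "known", "first", "only" and "open" are said of these compounds alone.

Of the compounds shown here, two built on the same core have been tested in a functional assay on the whole organism (strain Wistar albino) for inhibition, with Rattus norvegicus as the target, read by paw edema, with stated times of 30 min and 3 h, at a dose of 0.05 mmol/kg; a higher number here means more inhibition at the dose given (going by the name of the read-out), a lower number less inhibition. Compound 1 `NS(=O)(=O)c1ccc(N2N=C(c3cccc(O)c3)C[C@H]2c2ccccc2)cc1` gives 35.8%. Where compound 1 carries hydrogen on an aromatic carbon, compound 2 `COc1ccc([C@@H]2CC(c3cccc(O)c3)=NN2c2ccc(S(N)(=O)=O)cc2)cc1` carries a methoxy, and compound 2 gives 64.7%. Within the data shown here, that single change produced a number 28.9 percentage points higher from compound 1 to compound 2 (beyond the scatter), so compound 2 stands highest of the two numbers, with compound 1 its only neighbour and clearly below it.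

Compound 3 `Cc1ccc([C@@H]2CC(c3cccc(O)c3)=NN2c2ccc(S(N)(=O)=O)cc2)cc1` has not yet been measured. It differs from compound 2 by methyl in place of methoxy on an aromatic carbon. Among the measured compounds shown here, no measured pair shows this exact exchange; the one step at hand, hydrogen to methoxy at the same aromatic carbon, was sizeable and upward, which suggests that a group at this place matters but says nothing direct about methyl against methoxy. The expectation is therefore a small downward step, a number 9.7 percentage points lower from compound 2 to compound 3 (within the scatter), placing compound 3 nearer compound 2 than compound 1. For compound 3 in this assay the expected value is 55%, with a range from 38% to 72%.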

Compound 3, a percentage reported as inhibition, in the whole organism at one dose (the size of the read-out at that dose, not a potency): 64.7%
For compound 3 the middle estimate is 9.7 percentage points below the measured one; measured number inside the range.
By their numbers in this assay, from the lowest: compound 1; then compounds 2 and 3 (each within the scatter of the next).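

In this assay, the step with methyl in place of methoxy, para to a large group, reads no change at the digits printed from compound 2 to compound 3 (within the scatter), so the oxygen that methoxy carries and methyl lacks, along with its hydrogen-bond acceptor, leaves no mark on this read-out beyond the scatter. Methyl in place of hydrogen gives a number 28.9 percentage points higher from compound 1 to compound 3 (beyond the scatter), and this sits alongside the earlier a number 28.9 percentage points higher from compound 1 to compound 2 (beyond the scatter), which shows that the rise seen with methoxy does not depend on having oxygen at this place, since a single carbon is enough to produce it. Nothing among the data explains why compounds with these two groups read alike in this whole-animal test.

Only hydrogen, methyl and methoxy are shown at this carbon, so it remains open whether a longer chain such as propyl, a halogen such as chlorine, an amine or a carboxylic acid would keep the higher number or lose it. Each compound is also read at a single dose, which gives the size of the effect at that dose and leaves open whether compound 2 and compound 3 would still read alike at other doses.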